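Swapping a sulfonyl for a diazepane carbonyl

The source may report more compounds than this note shows. Statements on the series, on what has been measured and on what is new or still open speak of the compounds shown alone.

Values in a functional assay on DU-145 cells (Homo sapiens) for antiproliferative activity, read by MTT assay, with a stated time of 3 days; a lower number here means a stronger inhibitor, a higher number a weaker inhibitor:
Compound 1 `CCS(=O)(=O)Nc1ccc(-c2cc(=O)c3c(O)cc(OC)c(OC(C)C)c3o2)cc1` gives 17000 nM
Compound 2 `COc1cc(O)c2c(=O)cc(-c3ccc(NS(=O)(=O)C4CC4)cc3)oc2c1OC(C)C` gives 48700 nM
Compound 3 `COc1cc(O)c2c(=O)cc(-c3ccc(NC(=O)NC4CC4)cc3)oc2c1OC(C)C` gives 15600 nM

Compound 2 has the highest number of the three, so it is the weakest inhibitor here. Its neighbours are separated from it by a 2.9-fold higher number from compound 1 to compound 2 (0.46 log units; beyond the scatter) and a 3.1-fold lower number from compound 2 to compound 3 (0.49 log units; beyond the scatter).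

The untested compound 4 `COc1cc(O)c2c(=O)cc(-c3ccc(NC(=O)N4CCCNCC4)cc3)oc2c1OC(C)C` has (1,4-diazepan-1-yl)carbonyl in place of cyclopropylsulfonyl on a nitrogen on an aromatic ring.

The closest measured change is a 3.1-fold lower number from compound 2 to compound 3 (0.49 log units; beyond the scatter), where cyclopropylcarbamoyl replaces that same cyclopropylsulfonyl. The related swap of ethylsulfonyl for cyclopropylcarbamoyl gave a 1.1-fold lower number from compound 1 to compound 3 (0.04 log units; within the scatter), so such a swap does not always shift the number. Among the measured compounds shown here, no measured compound carries the seven-membered ring, and its contribution is unknown.

A modest drop in this assay is therefore expected, a 3.0-fold lower number from compound 2 to compound 4 (0.48 log units; beyond the scatter). The estimate for compound 4 is 16000 nM, with an expected range from 5000 nM to 50000 nM.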

Compound 4, half-maximal inhibitory concentration: 36000 nM
Compound 4: middle estimate off by 2.3-fold (0.35 log units), on the low side; low and high end bracket the measured number.
By their numbers in this assay, from the lowest: compounds 3 and 1 (each within the scatter of the next); then compounds 4 and 2 (each within the scatter of the next).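

In this assay the change to (1,4-diazepan-1-yl)carbonyl gives a 1.4-fold lower number from compound 2 to compound 4 (0.13 log units; within the scatter) and so produces no readable shift from cyclopropylsulfonyl on this nitrogen. A carbonyl in this place therefore does not settle the result on its own, and the group on the carbonyl carbon also counts: replacing cyclopropylamino with 1,4-diazepan-1-yl gives a 2.3-fold higher number from compound 3 to compound 4 (0.36 log units; beyond the scatter) and the comparison with the ethylsulfonyl compound gives a 2.1-fold higher number from compound 1 to compound 4 (0.33 log units; beyond the scatter) in the same assay. Nothing available here explains these steps.

Going by these compounds, it remains open whether a piperazine on the same carbonyl, or a methyl group on the free ring nitrogen of the 1,4-diazepan-1-yl, would move the number. On these data alone, all four compounds share one core, so whether these steps carry over to another core is also open.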